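A few compounds are considered here, and "the series" means these few. Any claim that something is new, unique, unknown or untested is made for them only; others in the source may bear on it.

Measured compounds and values:
Compound 1 `Cc1cccc(C#Cc2nc3c(s2)C(=O)NCC3)c1`: in an assay on HEK293 cells for positive allosteric modulation of metabotropic glutamate receptor 5 (Homo sapiens), read by FLIPR, with a stated time of 1 h (on this read-out higher numbers stand for an effect only at larger amounts of compound and lower numbers for an effect already at smaller amounts), compound 1 gives > 10000 nM, which is a limit of the assay and not a number.
Compound 2 `CN1CCc2nc(C#Cc3cccc(F)c3)sc2C1`: in this assay compound 2 gives > 10000 nM, again only a limit.
Compound 3 `Fc1cccc(C#Cc2nc3c(s2)CN(C2CCC2)CC3)c1`: in this assay compound 3 gives > 10000 nM, also a limit.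

Compound 3 therefore stands where every measured compound stands, at the limit of > 10000 nM in this assay, at which 3 of the 3 values shown sit, so no ranking among the three is possible. For the measured compounds named here, the only step recorded between two measured compounds that differ in one place, a step that the two limits leave unreadable from compound 2 to compound 3, has limits at both ends and its size cannot be read.

Compound 4 `O=C(C1CC(F)(F)C1)N1CCc2nc(C#Cc3cccc(F)c3)sc2C1` differs from compound 3 in one place: (3,3-difluorocyclobutyl)carbonyl in place of cyclobutyl on an amine nitrogen in a ring. Going by the values given here, this exchange of a plain cyclobutyl for a carbonyl-linked difluorocyclobutyl has no measured counterpart among the three compounds, so no step tells how large an effect to expect, in either direction. Given that every measured neighbour sits at the limit, compound 4 is expected to land in the same region, with a real chance of a readable number that could lie well on either side. The step of an at least 2.5-fold lower number from compound 3 to compound 4 (0.39 log units; beyond the scatter) is therefore only a rough expectation. For compound 4 the estimate is 4000 nM, with a range from 500 nM to 30000 nM.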

Compound 4, half-maximal effective concentration: 2.5 nM
Compound 4: the middle estimate sits 1600-fold (3.20 log units) above what was measured; measured number outside the range, below it.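

In this assay, the amine nitrogen in the six-membered ring proves to be a place where a single exchange can move the read-out greatly: (3,3-difluorocyclobutyl)carbonyl in place of cyclobutyl gives an at least 4000-fold lower number from compound 3 to compound 4 (3.60 log units; beyond the scatter), and the same group in place of methyl gives an at least 4000-fold lower number from compound 2 to compound 4 (3.60 log units; beyond the scatter). For the compounds shown here, both steps start from a limit of the assay, and the earlier compounds, all at limits, could not show that this position responds at all. Compound 4 is the only compound here with a readable number: the limit of > 10000 nM in this assay, at which 3 of the 4 values shown sit.

The entering group differs from cyclobutyl in two ways at once, with a carbonyl on the nitrogen and fluorine atoms on the ring, and the compounds shown do not tell which of these matters, or whether both are needed. A plain cyclobutylcarbonyl group and a 3,3-difluorocyclobutyl group bound directly to the nitrogen would separate the two, while an acetyl group would test whether the four-membered ring is needed at all.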